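This account rests on a few compounds, and the source may have more. Where it says the series, first, only, none or still open, it means among the compounds named here.

Compound 1 `COc1ccc(CNC(=O)/C=C/c2coc3cc(O)ccc3c2=O)cc1` gives 10000 nM in a functional assay (QGY7701 cells, Homo sapiens) for inhibition, read by MTT assay, with a stated time of 48 h; a higher number here means a weaker inhibitor, a lower number a stronger inhibitor. Compound 2 `COc1ccc(CNC(=O)/C=C/c2coc3cc(OC)ccc3c2=O)cc1` gives 15700 nM. Compound 3 `COc1ccc2c(=O)c(/C=C/C(=O)NCc3ccc(F)cc3F)coc2c1` gives only a limit of the assay, > 100000 nM.

Compound 4 `O=C(/C=C/c1coc2cc(O)ccc2c1=O)NCc1ccc(F)cc1F` has not been measured. It stands to compound 3 as compound 1 stands to compound 2: the change is hydrogen in place of methyl on an oxygen on an aromatic ring, the same change as hydrogen in place of methyl on an oxygen on an aromatic ring, which made a 1.6-fold lower number from compound 2 to compound 1 (0.20 log units; within the scatter). The cores of compound 2 and compound 3 differ by 2,4-difluorophenyl in place of 4-methoxyphenyl on a saturated chain carbon bound to an amide-type nitrogen, and that change made an at least 6.3-fold higher number from compound 2 to compound 3 (0.80 log units; beyond the scatter). Compound 3 sits at the limit of > 100000 nM in this assay, at which 1 of the 3 values shown sits. With the earlier step so small, the step that this estimate means, a number no higher from compound 3 to compound 4 (the limit leaves the size open), is expected to be about as small, pointing the same way. Compound 4 is expected to give about 100000 nM, between 40000 nM and 300000 nM, and may again be reported only as a limit.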

Compound 4, half-maximal inhibitory concentration: > 100000 nM
Compound 4: a limit, no number; the forecaster's own chance of this, stated with the estimate: 70%; the middle value sits exactly at the limit.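

In this assay, putting 2,4-difluorophenyl in place of 4-methoxyphenyl gives an at least 10-fold higher number from compound 1 to compound 4 (1.00 log units; beyond the scatter), so this change weakens inhibition on the core of compound 1 as well. The direction therefore carries over between these two cores, but this does not show that the size does, and two cores are a narrow test: the same change on two cores in this assay, an at least 6.3-fold higher number (0.80 log units; beyond the scatter) from compound 2 to compound 3 and an at least 10-fold higher number (1.00 log units; beyond the scatter) from compound 1 to compound 4; the limit leaves it open whether they differ

On these data alone, the step between compound 3 and compound 4 cannot be read, since both values are limits of the assay, so the effect of methoxy to hydroxy with 2,4-difluorophenyl remains unknown. As far as these compounds go, how this series would respond to an amine or a carboxylic acid in place of the hydroxy, or to a longer chain on the amide nitrogen, also stays open.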